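A few compounds are considered here, and "the series" means these few. Any claim that something is new, unique, unknown or untested is made for them only; others in the source may bear on it.

Among the measured compounds shown here, compound 2 `Cc1ccc(NS(C)(=O)=O)c2c1C(c1c[nH]cn1)CCC2` gives 389 nM in an assay on isolated protein for binding affinity to Alpha-1A adrenergic receptor (Rattus norvegicus), read by radioligand binding (a higher number here means a weaker inhibitor, a lower number a stronger inhibitor), and stands as the lowest of the two numbers measured so far. Compound 1 `COc1ccc(NS(C)(=O)=O)c2c1C(c1c[nH]cn1)CCC2` gives 1700 nM in this assay; replacing methoxy by methyl gave a 4.4-fold lower number from compound 1 to compound 2 (0.64 log units; beyond the scatter). Compound 3 `CS(=O)(=O)Nc1ccc(Cl)c2c1CCCC2c1c[nH]cn1` carries chloro in place of methyl on an aromatic carbon. For the measured compounds named here, only that single step bears on it, and it concerns a different exchange at the same aromatic carbon, so it offers limited guidance. The step of a 1.3-fold lower number from compound 2 to compound 3 (0.11 log units; within the scatter) is expected to remain within the scatter. Compound 3 is therefore estimated at 300 nM, with a range from 100 nM to 1000 nM.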

Compound 3, inhibition constant: 447 nM
Beside the measured number, compound 3's estimate is 1.5-fold (0.17 log units) below it; the measured number falls inside the stated range.
By their numbers in this assay, from the lowest: compounds 2 and 3 (each within the scatter of the next); then compound 1.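

At the aromatic carbon para to a methanesulfonamido group, a 1.1-fold higher number from compound 2 to compound 3 (0.06 log units; within the scatter) in this assay leaves chloro and methyl level. With a 3.8-fold lower number from compound 1 to compound 3 (0.58 log units; beyond the scatter) as well, compound 1 alone stands apart, and the methoxy separation is no longer seen with methyl only. No evidence at hand explains this.

Open, from the compounds shown here alone, is how a hydrogen, an amine or a longer chain would read at this aromatic carbon. Also open, going by these compounds, is whether chloro and methyl stay level on other cores.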